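The source may hold more compounds than are shown below. What is called first, only, known or untested is meant among the compounds shown, and "the series" means these compounds.

Measured in a functional assay on cells for antagonist activity at C-C chemokine receptor type 4 (Homo sapiens), read by fluorescence and calcium flux, with stated times of 2.5 s and 45 s; on this read-out higher numbers stand for weaker inhibition and lower numbers for stronger inhibition:
compound 1, `Cc1nn([C@H](C)c2ccc(Cl)cc2Cl)c2nc(N3CC[C@H](N4CCC[C@H]4CCS(C)(=O)=O)[C@H](C)C3)cnc12`: 104 nM
compound 2, `CC(c1ccc(Cl)cc1Cl)n1ncc2ncc(C3=CCN(C(=O)[C@H]4CCCCN4)CC3)nc21`: 275 nM
compound 3, `C[C@@H]1CC(c2cnc3c(C#N)nn([C@H](C)c4ccc(Cl)cc4Cl)c3n2)=CC[C@@H]1N1CCC[C@H]1C(N)=O`: 54 nM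

Compound 1 holds the second highest of the three numbers. Compound 3 lies nearest and within the scatter of compound 1, so no order between the two is drawn; compound 2 gives the higher number, and that gap is beyond the scatter. For the measured compounds named here, no single-point step between measured compounds is available, so the move to compound 4, `Cc1nn([C@H](C)c2ccc(Cl)cc2Cl)c2nc(N3CC[C@H](N4CCC[C@H]4CO)[C@H](C)C3)cnc12`, rests on the change alone: hydroxy in place of (methylsulfonyl)methyl on a saturated chain carbon bound to a saturated ring carbon. Compounds 2 and 3 differ from compound 1 in several places yet stay close to it, which speaks against a large shift here. For compound 4 in this assay a step of a 1.4-fold higher number from compound 1 to compound 4 (0.16 log units; within the scatter) is expected, not beyond the scatter and with no clear direction. Compound 4 is therefore estimated at 150 nM, with a range from 50 nM to 450 nM.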

Compound 4, half-maximal inhibitory concentration: 32 nM
The estimate for compound 4 lay 4.7-fold (0.67 log units) above the measured number, and the stated range ends above it.
By their numbers in this assay, from the lowest: compounds 4, 3 and 1 (each within the scatter of the next, the first and the last beyond it); then compound 2.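

Replacing (methylsulfonyl)methyl with hydroxy on a saturated chain carbon bound to a saturated ring carbon gives a 3.3-fold lower number from compound 1 to compound 4 (0.51 log units; beyond the scatter) in this assay, the only single-place step shown. This position therefore responds to the change, and the methylsulfonyl group is not required for inhibition at this level. No measured evidence bears on the cause of this step.

The step removes methylsulfonyl and introduces hydroxy at once, leaving open which of the two accounts for the lower number. Methoxy, an amine, a carboxylic acid or a longer hydroxyalkyl chain at this place could separate the two.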